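Hydroxy for Acetyl on an Aromatic Nitrogen

The compounds below may be only part of what the source reports. "The series", "measured", "known", "first", "only" and "open" are said of these compounds alone.

Compound 1 `CC(=O)Nc1ccc(CNc2cc(Br)cc3[nH]ncc23)cc1` stands highest of the two numbers recorded so far in an assay for inhibition of Indoleamine 2,3-dioxygenase 1 (Homo sapiens), with a stated time of 1 h, tested at 10 uM (on this read-out higher numbers stand for more inhibition at the one concentration tested (going by the name of the read-out) and lower numbers for less inhibition), where compound 1 gives 48%. Its nearest neighbour is compound 2 `Nc1ccccc1CNc1cc(Br)cc2[nH]ncc12`, which in this assay gives 36%, a number that lies beyond the scatter below that of compound 1. Among the measured compounds shown here, no single-point step between these two measured compounds is counted, so only their two values can be set side by side.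

Compound 3 `ONc1ccc(CNc2cc(Br)cc3[nH]ncc23)cc1` has not yet been measured in this assay. It differs from compound 1 by hydroxy in place of acetyl on a nitrogen on an aromatic ring. The measured pair offers no comparable exchange at that nitrogen, so the data give no direction for this change on their own.

With nothing to lean on but the two measured values, the expectation for compound 3 is a step of a number 8 percentage points lower from compound 1 to compound 3 (within the scatter), a move that stays close to the scatter and points slightly downward. Compound 3 is therefore estimated at 40%, with a range from 15% to 65%.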

Compound 3, a percentage reported as inhibition, at one concentration (the size of the read-out at that concentration, not a potency): "not active" (no number reported)
For compound 3 the study gives words and no number; the estimate stays without a comparison.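

In this assay, among the compounds shown here, compound 3 is reported as "not active" (no number reported) with no number, so no step from compound 1 to compound 3 can be read. The compounds shown leave open how large a change in inhibition the exchange of acetamido for hydroxyamino brings. No measured evidence here bears on this result.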